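The source may hold more compounds than are shown below. What is called first, only, known or untested is meant among the compounds shown, and "the series" means these compounds.

Measured so far in a functional assay on BGC-823 cells (Homo sapiens) for cytotoxicity, read by CCK-8 assay, with a stated time of 24 h; on this read-out lower numbers stand for stronger inhibition and higher numbers for weaker inhibition:

Compound 1, `C/C(=C\c1cc(-c2cccnc2)co1)C(N)=O`, gives > 50000 nM, which is a limit of the assay rather than a number.
Compound 2, `C/C(=C\c1cc(C2=CCCC2)co1)C(N)=O`, gives > 50000 nM, again a limit.
Compound 3, `C/C(=C\c1cc(-c2ccc(C)cc2)cs1)C(N)=O`, gives > 50000 nM, also a limit.

Compound 3 therefore stands at no particular point on a scale of numbers: its result is a limit, and the same holds for the other two, as the limit of > 50000 nM in this assay, at which 3 of the 3 values shown sit, records. Within the data shown here, none of the three compounds differs from another in only one place, so no measured step exists to lean on. Compound 4, `COc1ccc(-c2csc(/C=C(\C)C(N)=O)c2)cc1`, differs from compound 3 by methoxy in place of methyl on an aromatic carbon. With every measured value sitting at the same limit, there is no direction of change to read from the numbers, and no step beyond the usual scatter is expected from this exchange. The expected result for compound 4 in this assay is 50000 nM, within 20000 nM to 200000 nM. That estimate means a step of a number no higher from compound 3 to compound 4 (the limit leaves the size open), which is expected to be no change beyond the scatter, most likely reported again as a limit.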

Compound 4, half-maximal inhibitory concentration: > 50000 nM
Compound 4 ended at the assay's limit (the forecaster's own chance of this, stated with the estimate: 80%); the middle value lies on the limit itself.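

No step can be read from compound 3 to compound 4, because both results are limits rather than numbers: the limit of > 50000 nM in this assay, at which 4 of the 4 values shown sit.

The compounds shown leave open whether methoxy in place of methyl, or any other difference among them, changes the result in this assay.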